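Swapping the amine's sulfonyl for a trifluoroacetyl group

The source may hold more compounds than are shown below. What is called first, only, known or untested is meant among the compounds shown, and "the series" means these compounds.

Of the compounds shown here, three sharing one core have been measured in a functional assay on 3T3-L1 cells (Mus musculus) for inhibition, with a stated time of 20 min, tested at 20 uM; on this read-out higher numbers stand for more inhibition at the one concentration tested (going by the name of the read-out) and lower numbers for less inhibition. Compound 1 `Cc1ccc(S(=O)(=O)N(Cc2cn(Cc3ccccc3Cl)nn2)Cc2cn(S(=O)(=O)c3ccc(C)cc3)c3ccccc23)cc1` gives -4.8%. Compound 2 `CC(=O)N(Cc1cn(Cc2cccc(F)c2F)nn1)Cc1cn(S(=O)(=O)c2ccc(C)cc2)c2ccccc12` gives 39.5%. Compound 3 `Cc1ccc(S(=O)(=O)N(Cc2cn(Cc3cccc(F)c3F)nn2)Cc2cn(S(=O)(=O)c3ccc(C)cc3)c3ccccc23)cc1` gives the highest of the three numbers, 71.5%, with compound 2 nearest and compound 1 furthest. Two single changes lead up to it: a number 76.3 percentage points higher from compound 1 to compound 3 (beyond the scatter), and a number 32 percentage points higher from compound 2 to compound 3 (beyond the scatter).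

Compound 4 `Cc1ccc(S(=O)(=O)n2cc(CN(Cc3cn(Cc4cccc(F)c4F)nn3)C(=O)C(F)(F)F)c3ccccc32)cc1` has not yet been measured. It differs from compound 3 in one place: (trifluoromethyl)carbonyl in place of (4-methylphenyl)sulfonyl on an amine nitrogen. Among the measured compounds shown here, only one measured step bears on this change, the one in which compound 2 became compound 3 by gaining the (4-methylphenyl)sulfonyl on the amine nitrogen. Because a number 32 percentage points higher from compound 2 to compound 3 (beyond the scatter) came with putting that group in, taking it out again for a (trifluoromethyl)carbonyl is expected to give back part of that gain, estimated as a number 26.5 percentage points lower from compound 3 to compound 4 (beyond the scatter). Compound 4 is therefore expected to give 45% in this assay, with a range from 20% to 70%.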

Compound 4, a percentage reported as inhibition, at one concentration (the size of the read-out at that concentration, not a potency): 31.9%
Estimate against measurement, compound 4: 13.1 percentage points above; the measured number falls inside the stated range.
By their numbers in this assay, from the lowest: compound 1; then compounds 4 and 2 (each within the scatter of the next); then compound 3.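

In this assay, three groups can now be compared on the same amine nitrogen, and the (4-methylphenyl)sulfonyl of compound 3 stands clear of both carbonyl groups, with the change to (trifluoromethyl)carbonyl giving a number 39.6 percentage points lower from compound 3 to compound 4 (beyond the scatter). Trifluoromethyl in place of methyl on the carbonyl carbon gives a number 7.6 percentage points lower from compound 2 to compound 4 (within the scatter), so this read-out does not separate the acetyl of compound 2 from the (trifluoromethyl)carbonyl of compound 4. Nothing shown here gives a measured explanation for the difference between the sulfonyl and the carbonyl groups.

On these data alone, it remains open whether the higher number depends on the sulfonyl link or on the aromatic ring it carries, a question that a methylsulfonyl or a benzoyl group on this nitrogen could help to settle. As far as these compounds go, these comparisons all carry the 2,3-difluorophenyl group, so it is also open whether they hold with the 2-chlorophenyl group of compound 1.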